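The source may report more compounds than this note shows. Statements on the series, on what has been measured and on what is new or still open speak of the compounds shown alone.

Compound 3 `COc1ccc(-c2c(S(=O)(=O)c3ccc(OC)cc3)cnc3c(F)cccc23)cc1` is the starting point of this step. In an ADME assay on microsomes from liver (Homo sapiens) for metabolic stability, tested at 2.5 uM (a lower number here means slower removal, a higher number faster removal of the compound), compound 3 gives 2.12 mL/min, the second highest of the three numbers measured. Compound 1 `COc1cccc(-c2c(S(=O)(=O)c3ccc(C)c(F)c3)cnc3c(F)cccc23)c1` gives 4.02 mL/min in this assay, a number that lies within the scatter of the value of compound 3. Compound 2 `COc1ccc(S(=O)(=O)c2cnc3c(F)cccc3c2-c2ccc(Cl)cc2)cc1` gives 1.05 mL/min. For the measured compounds named here, the one recorded step is a 2.0-fold higher number from compound 2 to compound 3 (0.31 log units; beyond the scatter).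

Compound 4 `COc1ccc(S(=O)(=O)c2cnc3c(F)cccc3c2-c2cccc(OC)c2)cc1` differs from compound 3 in a single place: 3-methoxyphenyl in place of 4-methoxyphenyl on an aromatic carbon. Going by the values given here, no measured step covers this change directly; the step from compound 2 to compound 3 concerns a different group and a different kind of swap. Compound 1 does carry the 3-methoxyphenyl group that enters in compound 4, though on a different sulfonyl partner, and its number and that of compound 3 sit within the scatter of each other. The expectation is therefore a step of a 1.2-fold higher number from compound 3 to compound 4 (0.07 log units; within the scatter), with no change beyond the scatter. Compound 4 is estimated at 2.5 mL/min in this assay, with a range from 1.2 mL/min to 5 mL/min.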

Compound 4, intrinsic clearance in a liver preparation (reported as CLH), per the amount of preparation that the assay uses: 2.87 mL/min
The estimate for compound 4 lay 1.1-fold (0.06 log units) below the measured number; the range from low to high includes it.
By their numbers in this assay, from the lowest: compound 2; then compounds 3, 4 and 1 (each within the scatter of the next).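

In this assay, 3-methoxyphenyl in place of 4-methoxyphenyl gives a 1.4-fold higher number from compound 3 to compound 4 (0.13 log units; within the scatter) and so does not separate the two methoxyphenyl groups at this aromatic carbon. 3-Methoxyphenyl in place of 4-chlorophenyl gives a 2.7-fold higher number from compound 2 to compound 4 (0.44 log units; beyond the scatter) and, with a 2.0-fold higher number from compound 2 to compound 3 (0.31 log units; beyond the scatter) for the methoxy swap, sets both methoxyphenyl compounds apart from the chloro compound by a modest margin. For the compounds shown here, the sulfonyl sulfur is now read for the first time, and 4-methoxyphenyl in place of 3-fluoro-4-methylphenyl there gives a 1.4-fold lower number from compound 1 to compound 4 (0.15 log units; within the scatter) with the 3-methoxyphenyl group held constant.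

The compounds shown leave open how an amine or a carboxylic acid on either phenyl ring would read in this assay at these two places. The data shown offer no reason for any of these numbers.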